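Cytotoxicity limits across nitrofuran, trifluoromethylfuran and nitrothiophene amides

A few compounds are considered here, and "the series" means these few. Any claim that something is new, unique, unknown or untested is made for them only; others in the source may bear on it.

Compound 1 `CC1(C)CCN(S(=O)(=O)c2ccc(NC(=O)c3ccc([N+](=O)[O-])o3)cc2)CC1` is the starting point of the series. In an ADME assay on IMR-90 cells (Homo sapiens) for cytotoxicity, read by CellTiter-Blue, with a stated time of 46 h (on this read-out higher numbers stand for an effect only at larger amounts of compound and lower numbers for an effect already at smaller amounts), compound 1 gives > 25000 nM, which is a limit of the assay. Compound 2 `O=C(Nc1ccc(S(=O)(=O)N2CCC(F)CC2)cc1)c1ccc([N+](=O)[O-])o1` gives > 25000 nM in this assay, again a limit. Compound 3 `CC1(C)CCN(S(=O)(=O)c2ccc(NC(=O)c3ccc(C(F)(F)F)o3)cc2)CC1` likewise stands at a limit, > 25000 nM. One measured step is a step that the two limits leave unreadable from compound 1 to compound 2; the other is a step that the two limits leave unreadable from compound 1 to compound 3. All three compounds share (the limit of > 25000 nM in this assay, at which 3 of the 3 values shown sit). Compound 4 `CC1(C)CCN(S(=O)(=O)c2ccc(NC(=O)c3ccc([N+](=O)[O-])s3)cc2)CC1` differs from compound 3 by 5-nitrothiophen-2-yl in place of 5-(trifluoromethyl)furan-2-yl on a carbonyl carbon. Among the compounds with values here, no measured step bears directly on this exchange, and none of the three values is a number. Compound 4 is therefore expected to sit near 30000 nM, between 8000 nM and 100000 nM, most probably as a limit once more. The expected step is a step that the limit leaves unreadable from compound 3 to compound 4.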

Compound 4, half-maximal effective concentration: > 25000 nM
Compound 4: no number, only a limit (the forecaster's own chance of this, stated with the estimate: 70%); the middle value is on the limit's open side.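

Neither step to compound 4, from compound 3 or from compound 1, can be read, and each value is a limit rather than a number: the limit of > 25000 nM in this assay, at which 4 of the 4 values shown sit. In this assay the compounds shown leave open whether any of these exchanges changes the half-maximal effective concentration.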